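This account rests on a few compounds, and the source may have more. Where it says the series, first, only, none or still open, it means among the compounds named here.

Measured so far in a functional assay on SiHa cells (Homo sapiens) for cytotoxicity, read by MTT assay, with a stated time of 48 h; a lower number here means a stronger inhibitor, a higher number a weaker inhibitor:
compound 1, `CCCCCCCCCCCCCCCCCCNC(=O)[C@@H](N)[C@@H](C)O`, 39500 nM;
compound 2, `CCCCCCCCCCCCNC(=O)[C@@H](NC(=O)c1ccccc1)[C@@H](C)O`, 63900 nM;
compound 3, `CCCCCCCCCCCCNC(=O)[C@@H](NC(=O)c1ccco1)[C@@H](C)O`, 64300 nM.

Compound 2 stands second highest of the three numbers in this assay. Its nearest neighbour is compound 3, and the step of a 1.0-fold higher number from compound 2 to compound 3 (0.00 log units; within the scatter) is within the scatter. Its furthest neighbour is compound 1, which gives 39500 nM, a gap that is also within the scatter, so the three measured compounds cannot be placed in any order.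

Compound 4 is `CCCCCCCCCCCCCCCCCCNC(=O)[C@@H](NC(=O)c1ccccc1)[C@@H](C)O` and has not yet been measured in this assay. From compound 2 it differs by hexyl in place of hydrogen on a saturated chain carbon, ten or more bonds along the chain from an amide-type nitrogen. Within the data shown here, the one measured step, a 1.0-fold higher number from compound 2 to compound 3 (0.00 log units; within the scatter), concerns the group on the carbonyl carbon and not the chain, so it does not bear on this change. Compound 1 carries the same long chain as compound 4 but a free amine where compound 4 has the phenyl on a carbonyl carbon; its value and that of compound 2 are within the scatter of each other, which gives no sign that the chain length by itself moves the number. The expectation for compound 4 is therefore a step of a 1.3-fold lower number from compound 2 to compound 4 (0.11 log units; within the scatter) that stays within the scatter. Compound 4 is estimated at 50000 nM, within 18000 nM to 140000 nM.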

Compound 4, half-maximal inhibitory concentration: 38200 nM
Beside the measured number, compound 4's estimate is 1.3-fold (0.12 log units) above it, within the range that was stated.
By their numbers in this assay, from the lowest: compounds 4, 1, 2 and 3 (each within the scatter of the next).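

In this assay, the chain position now has its first direct reading: hexyl in place of hydrogen on a saturated chain carbon, ten or more bonds along the chain from an amide-type nitrogen, gives a 1.7-fold lower number from compound 2 to compound 4 (0.22 log units; within the scatter) and so cannot be told apart from repeat measurement. The amine nitrogen also has its first reading, since on the same long chain benzoyl in place of hydrogen on an amine nitrogen gives a 1.0-fold lower number from compound 1 to compound 4 (0.01 log units; within the scatter) and leaves no separation between the free amine and the benzamide. Nothing available bears on what lies behind either step.

All four compounds remain within the scatter of their neighbours, so neither the chain nor the group on the nitrogen has yet been shown to shift the number in this assay. Still open, on these data alone, are whether a longer chain than that of compound 4, or a carboxylic acid or an amine in place of hydrogen on the phenyl, would give a step beyond the scatter, and how the free amine behaves on the chain of compound 2.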